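The compounds below may be only part of what the source reports. "The series", "measured", "known", "first", "only" and "open" are said of these compounds alone.

Measured compounds:
compound 1 `FC(F)(F)c1cccc(N(C[C@@H]2CCCN3CCCC[C@H]23)/N=N/c2ccccc2)c1`: 75000 nM
compound 2 `CCOC(=O)N1CCN(/N=N/c2ccccc2)CC1`: 90000 nM

Both compounds were tested in an ADME assay on Vero cells (Chlorocebus sabaeus) for cytotoxicity, read by crystal violet staining; a higher number here means that more compound is tolerated, a lower number that less compound is tolerated. Compound 1 gives 75000 nM, and compound 2 gives 90000 nM. Compound 2 has the higher of the two numbers, but the gap to compound 1 lies within the usual scatter of repeated measurements, so on these data the two compounds are tolerated to the same degree.

Compound 3 `c1ccc(/N=N/N2CCN(c3ncccn3)CC2)cc1` has not yet been measured in this assay. It differs from compound 2 in one place: pyrimidin-2-yl in place of ethoxycarbonyl on an amine nitrogen in a ring. Within the data shown here, no measured pair shows the effect of such a change, so the expectation rests only on the two compounds at hand, whose numbers in this assay are close. The step from compound 2 to compound 3 is therefore expected to be small, a 1.3-fold lower number from compound 2 to compound 3 (0.11 log units; within the scatter), with no clear direction beyond the scatter. For compound 3 the estimated value in this assay is 70000 nM, with a range from 30000 nM to 160000 nM.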

Compound 3, half-maximal cytotoxic concentration: 65000 nM
Estimate against measurement, compound 3: 1.1-fold (0.03 log units) above; low and high end bracket the measured number.
By their numbers in this assay, from the lowest: compounds 3, 1 and 2 (each within the scatter of the next).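

In this assay, replacing ethoxycarbonyl with pyrimidin-2-yl on the amine nitrogen in the ring gives a 1.4-fold lower number from compound 2 to compound 3 (0.14 log units; within the scatter) and this step lies within the scatter. Among these compounds, this is the first measured change at this position, and it shows that a group with no ring can give way to a six-membered aromatic ring with no measurable shift in how much compound the cells tolerate. No available evidence bears on why the two groups give such similar results.

One replacement says little about the position as a whole, so a single methyl or a chain ending in a carboxylic acid on this nitrogen could still behave differently. On these data alone, the effect of changes elsewhere in compound 3 also remains open, such as a nitrile on the phenyl ring.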